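Swapping the Chloroacrylamide for a Branched Alkenyl Amide

The compounds below may be only part of what the source reports. "The series", "measured", "known", "first", "only" and "open" are said of these compounds alone.

Measured compounds:
Compound 1 `C=CC(=O)Nc1cc(Nc2nc(C)cc(-c3cn(C)c4ccccc34)n2)c(OC)cc1N(C)CCN(C)C`: 12600 nM
Compound 2 `C=C(Cl)C(=O)Nc1cc(Nc2nc(C)cc(-c3cn(C)c4ccccc34)n2)c(OC)cc1N(C)CCN(C)C`: 3640 nM

Compound 1 and compound 2 share one core and differ only in the group attached to the amide carbonyl. Among the compounds with values here, in a functional assay on HepG2 cells (Homo sapiens) for antiproliferative activity, read by MTT assay, with a stated time of 72 h (a higher number here means a weaker inhibitor, a lower number a stronger inhibitor), compound 2 gives 3640 nM, the lowest of the two numbers; its only neighbour is compound 1, and the step of a 3.5-fold lower number from compound 1 to compound 2 (0.54 log units; beyond the scatter) separates them.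

Compound 3 `COc1cc(N(C)CCN(C)C)c(NC(=O)/C=C\C(C)C)cc1Nc1nc(C)cc(-c2cn(C)c3ccccc23)n1` continues at the same place: 3-methylbut-1-en-1-yl in place of 1-chloroethenyl on a carbonyl carbon. Within the data shown here, no measured step covers such an exchange; the single step at hand, a 3.5-fold lower number from compound 1 to compound 2 (0.54 log units; beyond the scatter), concerns only a chloro on the chain and gives no guidance on replacing that chain with the 3-methylbut-1-en-1-yl group. With nothing to support a gain, the expectation is a weaker result, roughly a return toward compound 1, which is the step of a 4.1-fold higher number from compound 2 to compound 3 (0.61 log units; beyond the scatter) expected here. Compound 3 is therefore estimated at 15000 nM, with a likely range from 4000 nM to 50000 nM.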

Compound 3, half-maximal inhibitory concentration: 3550 nM
For compound 3 the middle estimate is 4.2-fold (0.63 log units) above the measured one; the whole stated range lies above it.
By their numbers in this assay, from the lowest: compounds 3 and 2 (each within the scatter of the next); then compound 1.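

In this assay, the chloro is not the only route away from the weaker vinyl amide. Replacing vinyl with 3-methylbut-1-en-1-yl on the carbonyl carbon gives a 3.5-fold lower number from compound 1 to compound 3 (0.55 log units; beyond the scatter) and so brings a gain of similar size without any chlorine. Exchanging 1-chloroethenyl for 3-methylbut-1-en-1-yl gives a 1.0-fold lower number from compound 2 to compound 3 (0.01 log units; within the scatter) and so leaves the two groups indistinguishable here, even though one carries chlorine and the other only carbon. Nothing shown here explains why these two different groups match.

As far as these compounds go, whether a longer alkenyl chain would keep this level or shift it remains open. So does the effect of an amine on the chain, such as a dimethylaminomethyl group, and of a saturated propanoyl amide with no double bond at all.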